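This account rests on a few compounds, and the source may have more. Where it says the series, first, only, none or still open, it means among the compounds named here.

Measured so far in a functional assay on HepG2 cells (Homo sapiens) for antiproliferative activity, read by MTT assay, with a stated time of 48 h; on this read-out lower numbers stand for stronger inhibition of growth and higher numbers for weaker inhibition of growth:
- compound 1 `CCCCCCCCN(Cc1ccc(C(=O)NO)cc1)c1ncc(-c2ccc(C)cc2)s1`: 8760 nM
- compound 2 `Cc1ccc(OCCCN(Cc2ccc(C(=O)NO)cc2)c2ncc(-c3ccc(C)cc3)s2)cc1`: 12200 nM

Compound 2, at 12200 nM, cannot be separated from compound 1, at 8760 nM; the two values lie within the scatter of each other.

The next compound is compound 3 `Cc1ccc(OCCCCN(Cc2ccc(C(=O)NO)cc2)c2ncc(-c3ccc(C)cc3)s2)cc1`. Its difference from compound 2 is (4-methylphenoxy)methyl in place of 4-methylphenoxy on a saturated chain carbon, three bonds along the chain from a nitrogen on an aromatic ring. It places (4-methylphenoxy)methyl in place of 4-methylphenoxy on a saturated chain carbon, three bonds along the chain from a nitrogen on an aromatic ring. Cut further out, the same change reads 3-(4-methylphenoxy)propyl to 4-(4-methylphenoxy)butyl.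

Among the compounds with values here, only one measured step bears on this change, a 1.4-fold higher number from compound 1 to compound 2 (0.14 log units; within the scatter). It falls at the same place in the structure and stays within the scatter, although it exchanges pentyl for 4-methylphenoxy. Within the data shown here, no pair yet tests a change of this kind directly, so the evidence is thin.

In this assay, no step beyond the scatter and no settled direction are therefore expected. The expected step is a 1.0-fold lower number from compound 2 to compound 3 (0.01 log units; within the scatter). For compound 3 the estimate is 12000 nM, with an expected range from 5500 nM to 26000 nM.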

Compound 3, concentration for 50% growth inhibition: 11000 nM
The estimate for compound 3 lay 1.1-fold (0.04 log units) above the measured number; the range from low to high includes it.
By their numbers in this assay, from the lowest: compounds 1, 3 and 2 (each within the scatter of the next).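

In this assay, 4-(4-methylphenoxy)butyl in place of 3-(4-methylphenoxy)propyl gives a 1.1-fold lower number from compound 2 to compound 3 (0.04 log units; within the scatter) and so adds a second chain length to the series that cannot be separated from the first. With 4-methylphenoxy in place of butyl on a saturated chain carbon, four bonds along the chain from a nitrogen on an aromatic ring, the series gives a 1.3-fold higher number from compound 1 to compound 3 (0.10 log units; within the scatter) and shows that the exchange for the plain alkyl chain stays within the scatter at this place as well as at the place three bonds along. All three compounds therefore remain indistinguishable in this read-out, and no independent measurement is available to interpret that result.

On these data alone, it remains open whether any group at this chain end can move the growth-inhibition number beyond the scatter, for example an amine or a carboxylic acid in place of 4-methylphenoxy. A longer chain such as 5-(4-methylphenoxy)pentyl would show whether the indifference to chain length extends past 4-(4-methylphenoxy)butyl.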